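Switching the aryl group on the triazole-type ring nitrogen

The source may hold more compounds than are shown below. What is called first, only, known or untested is meant among the compounds shown, and "the series" means these compounds.

Of the compounds shown here, three have been measured so far in a functional assay on A549 cells (Homo sapiens) for cytotoxicity, read by MTT assay, with a stated time of 24 h; on this read-out lower numbers stand for stronger inhibition and higher numbers for weaker inhibition. Compound 1 `Fc1ccc(-n2cc(COc3ccccc3-c3nc4ccccc4s3)nn2)cc1Cl` gives 16300 nM, compound 2 `FC(F)(F)Oc1ccc(-c2cc(COc3ccccc3-c3nc4ccccc4s3)on2)cc1` gives 23900 nM, and compound 3 `Fc1ccc(-n2cc(COc3ccccc3-c3nc4ccccc4s3)nn2)cc1` gives 23300 nM. Compound 3 thus holds the second highest of the three numbers, but both of its neighbours lie within the scatter of it, so no ordering among them can be claimed. Going by the values given here, the only single-point step so far, a 1.4-fold higher number from compound 1 to compound 3 (0.16 log units; within the scatter), is likewise within the scatter.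

Compound 4 `FC(F)(F)c1cccc(-n2cc(COc3ccccc3-c3nc4ccccc4s3)nn2)c1` differs from compound 3 in one place: 3-(trifluoromethyl)phenyl in place of 4-fluorophenyl on an aromatic nitrogen. Among the compounds with values here, the step from compound 1 to compound 3 also changed the group on this same aromatic ring and produced nothing beyond the scatter, and no other measured pair bears on the change. On that basis the step of a 1.1-fold lower number from compound 3 to compound 4 (0.02 log units; within the scatter) in this assay is expected to stay within the scatter, with no clear direction. Compound 4 is therefore estimated at 22000 nM, with a likely range from 9000 nM to 55000 nM.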

Compound 4, half-maximal inhibitory concentration: 11100 nM
Beside the measured number, compound 4's estimate is 2.0-fold (0.30 log units) above it, and the stated range covers the measured number.
By their numbers in this assay, from the lowest: compounds 4, 1, 3 and 2 (each within the scatter of the next, the first and the last beyond it).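

In this assay, going by these compounds alone, replacing 4-fluorophenyl with 3-(trifluoromethyl)phenyl on the aromatic nitrogen gives a 2.1-fold lower number from compound 3 to compound 4 (0.32 log units; beyond the scatter), the first single-place step here beyond the scatter, so the aryl group at this position can move the number, though only modestly. The comparison with the 3-chloro-4-fluorophenyl group is weaker: a 1.5-fold lower number from compound 1 to compound 4 (0.17 log units; within the scatter), so compound 4 cannot be set apart from compound 1. Nothing available explains the shift.

The single step from compound 3 to compound 4 alters both the substituent and its printed ring position, so the compounds shown cannot separate the two changes; 4-(trifluoromethyl)phenyl or 3-fluorophenyl would address that. They also leave open how this assay responds to an aryl group carrying an amine or a carboxylic acid at this position.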